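The compounds below may be only part of what the source reports. "The series", "measured", "known", "first", "only" and "open" are said of these compounds alone.

Three compounds share one core, a urea joined to a trifluoromethyl-bearing ring on one side and to an aryl ether on the other. Compound 1 `O=C(Nc1ccc(Oc2ccncn2)cc1)Nc1cccc(C(F)(F)F)c1` carries no substituent on the ether-linked six-membered ring with two nitrogens; in an assay on isolated protein for inhibition of serine/threonine-protein kinase TNNI3K (Homo sapiens) (a lower number here means a stronger inhibitor, a higher number a weaker inhibitor), compound 1 gives 160 nM. Compound 2 `COc1cc(Oc2ccc(NC(=O)Nc3cccc(C(F)(F)F)c3)cc2)ncn1` adds a methoxy group there and gives 4000 nM, a change of a 25-fold higher number from compound 1 to compound 2 (1.40 log units; beyond the scatter). Compound 3 `CN(C)c1cc(Oc2ccc(NC(=O)Nc3cccc(C(F)(F)F)c3)cc2)ncn1` adds a dimethylamino group at the same place and gives 2500 nM, a change of a 16-fold higher number from compound 1 to compound 3 (1.19 log units; beyond the scatter). Between the two substituted compounds the step is a 1.6-fold lower number from compound 2 to compound 3 (0.20 log units; within the scatter), so compound 3 stands second highest of the three numbers, close to compound 2 and far from compound 1.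

Compound 4 `O=C(Nc1ccc(Oc2cc(NCCO)ncn2)cc1)Nc1cccc(C(F)(F)F)c1` differs from compound 3 by (2-hydroxyethyl)amino in place of dimethylamino on an aromatic carbon. For the measured compounds named here, the relevant steps are the two that place a group at this carbon, both large, and the one that exchanges one group for another, which stayed within the scatter. The new change is again an exchange of one group for another at the same place, so no step beyond the scatter is expected in this assay, giving an expected no change at the digits printed from compound 3 to compound 4 (within the scatter). Compound 4 is therefore estimated at 2500 nM, with a range from 900 nM to 7000 nM.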

Compound 4, half-maximal inhibitory concentration: 32 nM
The estimate for compound 4 lay 78-fold (1.89 log units) above the measured number; the measured number lies below the stated range.
By their numbers in this assay, from the lowest: compound 4; then compound 1; then compounds 3 and 2 (each within the scatter of the next).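

Before this result, every group placed at this carbon of the shared core had raised the number, yet in this assay the exchange of dimethylamino for (2-hydroxyethyl)amino gives a 78-fold lower number from compound 3 to compound 4 (1.89 log units; beyond the scatter), and the exchange of methoxy for the same group gives a 130-fold lower number from compound 2 to compound 4 (2.10 log units; beyond the scatter). The position therefore accepts a substituent, and what counts is which group sits there, not merely whether one is present: set against the bare carbon of compound 1, the change is a 5.0-fold lower number from compound 1 to compound 4 (0.70 log units; beyond the scatter), so a group here can give a stronger inhibitor than hydrogen does. The entering group differs from dimethylamino in its hydrogen-bond donors and its oxygen, but nothing available here ties the gain to either feature.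

Going by these compounds, it remains open whether the amine hydrogen, the terminal hydroxyl or both are needed, a question that a plain ethylamino group or a (2-methoxyethyl)amino group would help to separate. Also open, on these data alone, is how far the chain can change, for instance to a longer (3-hydroxypropyl)amino chain or to one ending in a carboxylic acid, while the number stays this low.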